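This account rests on a few compounds, and the source may have more. Where it says the series, first, only, none or still open, it means among the compounds named here.

Compound 1 `O=C(NO)c1cccc(-c2cn([C@@H]3C[C@@H](C(=O)O)N(CCCc4ccccc4)C3)nn2)c1` in an assay on Sf9 cells for inhibition of histone deacetylase 11 (Homo sapiens), read by fluorescence, tested at 0.5 uM (on this read-out higher numbers stand for more inhibition at the one concentration tested (going by the name of the read-out) and lower numbers for less inhibition), gives < 10%, a limit of the assay. Compound 2 `O=C(NO)c1ccc(-c2cn([C@H]3C[C@@H](C(=O)O)N(CCCc4ccccc4)C3)nn2)cc1` in this assay gives 14%. Compound 3 `O=C(NO)c1cccc(-c2cn([C@H]3C[C@H](C(=O)O)N(CCCc4ccccc4)C3)nn2)c1` in this assay gives < 10%, again a limit and not a number.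

Compound 3 thus stands at the limit, where two of the three values shown sit (the limit of < 10% in this assay, at which 2 of the 3 values shown sit). Within the data shown here, the one measured step that reaches it, a step that the two limits leave unreadable from compound 1 to compound 3, cannot be sized because the limit of < 10% in this assay, at which 2 of the 3 values shown sit, holds both of its ends, and it rests on (the fact that compounds 1 and 3 differ only in the configuration as drawn). Compound 4 `O=C(NO)c1cccc(-c2cn([C@H]3C[C@@H](C(=O)O)N(CCCc4ccccc4)C3)nn2)c1` differs from compound 3 by the two compounds have the same atoms and bonds and differ only in configuration as drawn: 1 of 2 stereo elements differ; a stereocentre at a saturated ring carbon is drawn R in compound 3 and S in compound 4. Among the measured compounds shown here, no measured step bears directly on this change; compound 2 is the only value shown as a number. Compound 4 is therefore expected to stay close to the limit, with a number no lower from compound 3 to compound 4 (the limit leaves the size open) expected to lie within the scatter. The estimate for compound 4 in this assay is 10%, between 3% and 20%.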

Compound 4, a percentage reported as inhibition, at one concentration (the size of the read-out at that concentration, not a potency): < 10%
Compound 4: a limit, no number; the forecaster's own chance of this, stated with the estimate: 50%; the middle value sits exactly at the limit.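

With compound 4, a third configuration of the 3-(hydroxycarbamoyl)phenyl series also stays at the limit in this assay, so no configuration shown for this group gives a readable number. The change of 3-(hydroxycarbamoyl)phenyl in place of 4-(hydroxycarbamoyl)phenyl gives a number at least 4 percentage points lower from compound 2 to compound 4 (that floor lies within the scatter), so this change is not shown to exceed the usual scatter. The configuration steps among compound 1, compound 3 and compound 4 cannot be read: the limit of < 10% in this assay, at which 3 of the 4 values shown sit.

The compounds shown leave open how other configurations behave with 4-(hydroxycarbamoyl)phenyl. They also leave open whether a methyl ester in place of the carboxylic acid, or a benzyl group in place of the phenylpropyl chain, would move the value off the limit.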